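This account rests on a few compounds, and the source may have more. Where it says the series, first, only, none or still open, it means among the compounds named here.

Working notes on the allylphenol biaryl series in an assay on isolated protein for inhibition of Maltase-glucoamylase (Homo sapiens), with stated times of 15 min and 10 min, tested at 64 uM; a higher number here means more inhibition at the concentration tested (going by the name of the read-out), a lower number less inhibition.

Three compounds differ only in the amine carried on a saturated chain carbon bound to an aromatic carbon. Compound 1 `C=CCc1ccc(O)c(-c2cc(CC=C)cc(CN(C)C(C)C)c2O)c1` gives 3.4%. Compound 2 `C=CCc1ccc(O)c(-c2cc(CC=C)cc(CN(CC(C)C)CC(C)C)c2O)c1` gives 3.8%. Compound 3 `C=CCc1ccc(O)c(-c2cc(CC=C)cc(CN(CCCC)CCCC)c2O)c1` gives 8.2%. The steps between them are a number 0.4 percentage points higher from compound 1 to compound 2 (within the scatter), a number 4.8 percentage points higher from compound 1 to compound 3 (within the scatter) and a number 4.4 percentage points higher from compound 2 to compound 3 (within the scatter); each lies within the scatter of this assay. Compound 3 holds the highest of the three numbers, but its nearest neighbour compound 2 and its furthest neighbour compound 1 both sit within the scatter of it, so no order among the three can be read from these data.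

Compound 4 `C=CCc1ccc(O)c(-c2cc(CC=C)cc(CN3CCC(C)CC3)c2O)c1` is not yet measured. Its structural difference from compound 3 is 4-methylpiperidin-1-yl in place of dibutylamino on a saturated chain carbon bound to an aromatic carbon. Among the compounds with values here, the steps that bear on it are those that swapped one amine for another at the same place: the steps from compound 1 and from compound 2 to compound 3 moved nothing beyond the scatter, and the step from compound 1 to compound 2 likewise. With three amine changes all flat at this concentration, the expected step to compound 4 is a number 2.2 percentage points lower from compound 3 to compound 4 (within the scatter), no direction beyond the scatter. Compound 4 is therefore estimated at 6%, with a range of 0% to 16%.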

Compound 4, a percentage reported as inhibition, at one concentration (the size of the read-out at that concentration, not a potency): 6.3%
Compound 4: middle estimate off by 0.3 percentage points, on the low side; the measured number falls inside the stated range.
By their numbers in this assay, from the lowest: compounds 1, 2, 4 and 3 (each within the scatter of the next).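

Within the data shown here, compound 4 brings a ring amine to this saturated chain carbon bound to an aromatic carbon, where the earlier compounds carried only open-chain amines. In this assay, the ring does not set it apart from any of them: the steps are a number 1.9 percentage points lower from compound 3 to compound 4 (within the scatter), a number 2.5 percentage points higher from compound 2 to compound 4 (within the scatter) and a number 2.9 percentage points higher from compound 1 to compound 4 (within the scatter). The four amines therefore read as one flat group at this position, and neither the change to one six-membered non-aromatic ring nor the change from 9 heavy atoms in dibutylamino to 7 in 4-methylpiperidin-1-yl gives a step that can be read; nothing available explains this flatness.

As far as these compounds go, all four groups at this position are amines whose nitrogen carries only carbon substituents, so it remains open whether a morpholine, a primary amine or a carboxylic acid here would move the number beyond the scatter. Each compound also has a single read-out at one concentration, which leaves open both its potency and the contribution of the allyl and hydroxyl groups on the shared core.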